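The compounds below may be only part of what the source reports. "The series", "measured", "known", "first", "only" and "open" are said of these compounds alone.

Measured compounds: compound 1 `C=C(Br)C(=O)Nc1cccc(/C=C2\SC(=O)N(Cc3ccc(C)cc3)C2=O)c1` gives 1200 nM in a functional assay on HeLa cells (Homo sapiens) for cytotoxicity, read by cell counting, with a stated time of 4 days; on this read-out higher numbers stand for weaker inhibition and lower numbers for stronger inhibition; compound 2 `CC(C)(C)c1ccc(CN2C(=O)S/C(=C\c3cccc(N)c3)C2=O)cc1` gives 145000 nM; compound 3 `C=C(Br)C(=O)Nc1cccc(/C=C2\SC(=O)N(Cc3ccc(F)cc3)C2=O)c1` gives 800 nM.

Compound 3 has the lowest number of the three. Among the measured compounds shown here, its nearest neighbour is compound 1, and the single measured step, a 1.5-fold lower number from compound 1 to compound 3 (0.18 log units; within the scatter), is within the scatter. For the measured compounds named here, compound 2 carries the tert-butyl group but not the bromoacrylamide, and its value shows a much higher number; no step to compound 3 is counted for it.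

Compound 4 `C=C(Br)C(=O)Nc1cccc(/C=C2\SC(=O)N(Cc3ccc(C(C)(C)C)cc3)C2=O)c1` differs from compound 3 by tert-butyl in place of fluoro on an aromatic carbon. Going by the values given here, the only step that bears on it, from compound 1 to compound 3, stayed within the scatter, so no step beyond the scatter is expected here: the estimate for compound 4 is 1000 nM (range 400 nM to 3000 nM), meaning an expected step of a 1.3-fold higher number from compound 3 to compound 4 (0.10 log units; within the scatter).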

Compound 4, half-maximal inhibitory concentration: 2800 nM
Beside the measured number, compound 4's estimate is 2.8-fold (0.45 log units) below it, and the stated range covers the measured number.
By their numbers in this assay, from the lowest: compounds 3 and 1 (each within the scatter of the next); then compound 4; then compound 2.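

In this assay, among the compounds shown here, tert-butyl at this aromatic carbon gives the first change of the 4-substituent that lies beyond the scatter (a 3.5-fold higher number from compound 3 to compound 4 (0.54 log units; beyond the scatter); a 2.3-fold higher number from compound 1 to compound 4 (0.37 log units; beyond the scatter)), both steps modest. The (1-bromoethenyl)carbonyl group on the nitrogen weighs far more, with a large step (a 52-fold lower number from compound 2 to compound 4 (1.71 log units; beyond the scatter)) measured in the presence of tert-butyl. No measurement at hand bears on the reason for these steps.

Still open, on these data alone, is whether an amine, a hydroxyl or a carboxylic acid at this aromatic carbon would stay near compound 3. Also open, as far as these compounds go, is what an unbrominated acrylamide on the nitrogen would give.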